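The source may hold more compounds than are shown below. What is called first, only, known or untested is meant among the compounds shown, and "the series" means these compounds.

Compound 2 `CCn1c(CC(C)C)nc2ccsc2c1=O` stands at the high end of the three numbers in hand. In an assay on cells for inhibition of high affinity 3',5'-cyclic-AMP phosphodiesterase 7A (Homo sapiens), read by scintillation counting and cAMP accumulation, with a stated time of 30 min (a higher number here means a weaker inhibitor, a lower number a stronger inhibitor), compound 2 gives 4700 nM, which makes it the weakest inhibitor of the set. Compound 3 `CCn1c(N[C@H]2CC[C@H](C(=O)O)CC2)nc2ccsc2c1=O` gives 1300 nM in this assay, and compound 1 `CCn1c(NC(C)C)nc2c(-c3ccnc(OC)c3)csc2c1=O` gives 4.6 nM, far below both. Both compound 1 and compound 3 carry a nitrogen-linked substituent on the shared core, whereas compound 2 carries a carbon chain there.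

Compound 4 `CCn1c(NC2CCC2)nc2ccsc2c1=O` is not yet measured. It differs from compound 2 in one place: cyclobutylamino in place of isobutyl on an aromatic carbon. For the measured compounds named here, no measured pair shows this exact step, so its size has to be judged from the two nitrogen-linked analogues. Since compound 1 with 4.6 nM and compound 3 with 1300 nM both sit below compound 2, a move toward lower numbers is expected for compound 4, and the step of a 12-fold lower number from compound 2 to compound 4 (1.07 log units; beyond the scatter) is estimated as moderate rather than as large as the gap to compound 1, which carries a further substituent. Compound 4 is expected to give about 400 nM in this assay, within a range from 60 nM to 2500 nM.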

Compound 4, half-maximal inhibitory concentration: 300 nM
Compound 4: middle estimate off by 1.3-fold (0.12 log units), on the high side, within the range that was stated.
By their numbers in this assay, from the lowest: compound 1; then compound 4; then compound 3; then compound 2.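

In this assay, replacing isobutyl with cyclobutylamino on the aromatic carbon between two ring nitrogen atoms gives a 16-fold lower number from compound 2 to compound 4 (1.19 log units; beyond the scatter), a large step and the first that can be read directly at this position. The change brings in a nitrogen, a four-membered ring of carbon only and a hydrogen-bond donor together, so this single step cannot assign the drop in the number to any one of them. Nothing measured here explains why the number falls.

The compounds shown leave open whether an open-chain isobutylamino group would give a similar number, or whether a cyclobutyl group attached directly through carbon would. They also leave open whether a secondary amine must sit at this position, since a tertiary amine such as dimethylamino does not appear among them.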